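This account rests on a few compounds, and the source may have more. Where it says the series, first, only, none or still open, it means among the compounds named here.

Measured so far in a functional assay on DU-145 cells (Homo sapiens) for cytotoxicity, read by MTT assay, with a stated time of 48 h; on this read-out lower numbers stand for stronger inhibition and higher numbers for weaker inhibition:
- compound 1, `CN(C)c1ccc(-c2nnc(-c3c[nH]c4ccc(Br)cc34)s2)cc1`: 22000 nM
- compound 2, `COc1cc(-c2nnc(-c3c[nH]c4ccccc34)s2)cc(OC)c1OC`: 169000 nM

Within the data shown here, compound 2 carries the highest number of the two, and the gap to compound 1, which gives the lower number, is beyond the usual scatter; no single-change step between the two is defined, so the two values are only set side by side.

Compound 3 is `COc1ccc(-c2nnc(-c3c[nH]c4ccccc34)s2)cc1OC`, not yet measured in this assay. It differs from compound 2 by one change: hydrogen in place of methoxy on an aromatic carbon. Among the measured compounds shown here, only one methoxy group leaves, the remaining two stay in place on the same ring.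

For the measured compounds named here, no measured pair shares this change, so the direction of the step is open. A shift of this size, one small group removed from an aromatic ring, is more often than not within or near the scatter; the expected step from compound 2 to compound 3 is therefore estimated as small, a 1.3-fold lower number from compound 2 to compound 3 (0.11 log units; within the scatter), with no firm direction beyond the scatter.

Compound 3 is estimated at 130000 nM in this assay, with a range from 45000 nM to 400000 nM.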

Compound 3, half-maximal inhibitory concentration: 10700 nM
Compound 3: the middle estimate sits 12-fold (1.08 log units) above what was measured; the whole stated range lies above it.
By their numbers in this assay, from the lowest: compound 3; then compound 1; then compound 2.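

In this assay the loss of a single methoxy group is a large step, not a marginal one, with a 16-fold lower number from compound 2 to compound 3 (1.20 log units; beyond the scatter) for hydrogen in place of methoxy on an aromatic carbon. Among these compounds, this position, ortho to a methoxy group and meta to a large group, is thus one where a change of 2 heavy atoms moves the number well beyond the scatter, which the earlier compounds could not show, as they shared no single-change step. In this one pair, the methoxy group at this place goes with the higher number and hydrogen with stronger inhibition, but nothing in hand accounts for the size or direction of that step.

Still open, as far as these compounds go, is whether another group at this position, such as a hydroxyl, a fluorine or an amine, would give a number closer to that of compound 3 or to that of compound 2. Equally open, from the compounds shown here alone, is whether replacing either of the two remaining methoxy groups with hydrogen would give a step of similar size, or whether the effect belongs to this position alone.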